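Replacing the aryl group in a cytotoxic series: working notes

The source may hold more compounds than are shown below. What is called first, only, known or untested is meant among the compounds shown, and "the series" means these compounds.

Measured in a functional assay on PC-3 cells (Homo sapiens) for cytotoxicity, read by MTT assay, with a stated time of 48 h (a lower number here means a stronger inhibitor, a higher number a weaker inhibitor), so far:
- compound 1 `Cc1ccc(C)c(/C=C/[C@](C)(O)CC[C@@H]2[C@@]3(C)CCCC(C)(C)[C@@H]3CC[C@@]2(C)O)c1` gives 176 nM
- compound 2 `COc1cccc(OC)c1/C=C/[C@](C)(O)CC[C@@H]1[C@@]2(C)CCCC(C)(C)[C@@H]2CC[C@@]1(C)O` gives 4000 nM
- compound 3 `Cc1cccc(C)c1/C=C/[C@](C)(O)CC[C@@H]1[C@@]2(C)CCCC(C)(C)[C@@H]2CC[C@@]1(C)O` gives 278 nM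

Compound 2 has the highest number of the three. Compound 4 `CC1(C)CCC[C@]2(C)[C@@H](CC[C@@](C)(O)/C=C/c3ccc(F)cc3)[C@](C)(O)CC[C@@H]12` differs from it as follows: 4-fluorophenyl in place of 2,6-dimethoxyphenyl on a double-bonded chain carbon bound to a double-bonded chain carbon (4-fluorophenyl in place of 2,6-dimethoxyphenyl, on a double-bonded chain carbon bound to a double-bonded chain carbon).

Two measured steps leave or enter 2,6-dimethoxyphenyl at this place, and both are large: a 23-fold higher number from compound 1 to compound 2 (1.36 log units; beyond the scatter) and a 14-fold lower number from compound 2 to compound 3 (1.16 log units; beyond the scatter). The step of a 1.6-fold higher number from compound 1 to compound 3 (0.20 log units; within the scatter) shows no separation between the two dimethylphenyl compounds. Among the measured compounds shown here, no fluorinated compound has been measured, so a large fall in this assay is expected, though a less certain one.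

The expected step is a 6.7-fold lower number from compound 2 to compound 4 (0.82 log units; beyond the scatter) in size. Compound 4 is estimated at 600 nM within a range of 150 nM to 2500 nM in this assay.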

Compound 4, half-maximal inhibitory concentration: 82 nM
Beside the measured number, compound 4's estimate is 7.3-fold (0.86 log units) above it, and the stated range ends above it.
By their numbers in this assay, from the lowest: compound 4; then compounds 1 and 3 (each within the scatter of the next); then compound 2.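

In this assay the 4-fluorophenyl group on a double-bonded chain carbon gives the strongest compound of the four, with a 49-fold lower number from compound 2 to compound 4 (1.69 log units; beyond the scatter) large, and both a 3.4-fold lower number from compound 3 to compound 4 (0.53 log units; beyond the scatter) and a 2.1-fold lower number from compound 1 to compound 4 (0.33 log units; beyond the scatter) modest but beyond the scatter. This position therefore tolerates an aryl group carrying neither methyl nor methoxy groups, and such a group improves on both dimethylphenyl compounds. Nothing available explains this order.

Open, on these data alone, is whether fluorine itself contributes, which a plain phenyl or a 4-chlorophenyl group would test. Also open, as far as these compounds go, is how a pyridine ring would read at this place.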